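The source may hold more compounds than are shown below. What is called first, only, known or untested is meant among the compounds shown, and "the series" means these compounds.

The series rests on a shared core, shown in compound 1 `O=c1[nH]cc(-c2ccccc2)o1`. In an assay on isolated protein for inhibition of acid ceramidase (Homo sapiens), read by LC-MS, with a stated time of 1 h (on this read-out lower numbers stand for stronger inhibition and higher numbers for weaker inhibition), compound 1 gives "not active" (no number reported). Compound 2 `O=C(NCCCCc1ccccc1)n1cc(-c2ccccc2)oc1=O` extends that core with a longer chain ending in a phenyl ring; in this assay compound 2 gives 90 nM. Compound 3 `COc1ccccc1-c1cn(C(=O)NCCCCc2ccccc2)c(=O)o1` differs from compound 2 by methoxy in place of hydrogen on an aromatic carbon, and in this assay compound 3 gives 177 nM. Among the compounds with values here, the step of a 2.0-fold higher number from compound 2 to compound 3 (0.29 log units; within the scatter) is the only single change measured so far, and it stays within the scatter. Among the two numbered results compound 3 holds the higher number, but its distance from compound 2 is within the scatter, so no order between the two can be claimed.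

Compound 4 `O=C(NCCCCc1ccccc1)n1cc(-c2ccncc2)oc1=O` is the next compound. Its change from compound 3 is pyridin-4-yl in place of 2-methoxyphenyl on an aromatic carbon. Within the data shown here, no measured step exchanges one aromatic ring for another, so the only bearing comes from the methoxy step, whose small size gives no sign that variation at this ring moves the number far. Compound 4 is therefore expected to land close to compound 3, with a step of a 1.1-fold higher number from compound 3 to compound 4 (0.05 log units; within the scatter) not beyond the scatter. The estimate for compound 4 in this assay is 200 nM, within a range from 70 nM to 600 nM.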

Compound 4, half-maximal inhibitory concentration: 18 nM
Compound 4: middle estimate off by 11-fold (1.05 log units), on the high side; measured number below the stated range.
By their numbers in this assay, from the lowest: compound 4; then compounds 2 and 3 (each within the scatter of the next).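

In this assay the exchange of 2-methoxyphenyl for pyridin-4-yl gives a 9.8-fold lower number from compound 3 to compound 4 (0.99 log units; beyond the scatter) and the exchange of phenyl for pyridin-4-yl gives a 5.0-fold lower number from compound 2 to compound 4 (0.70 log units; beyond the scatter) and thus two steps beyond the scatter, whereas the methoxy step alone had stayed within it. The aromatic carbon next to the ring oxygen therefore proves to be a place where the number does respond to the group it carries, and compound 4, with its six-membered aromatic ring holding one hetero atom, stands lowest of the three numbered compounds, while the two rings of carbon only cannot be ordered against each other. The information at hand offers no explanation for this drop in the number.

The compounds shown leave open whether the nitrogen must sit where it does in pyridin-4-yl, since pyridin-3-yl, pyridin-2-yl or a pyrimidine ring at this place would each test that. On these data alone, it also stays open whether the same gain would hold with a shorter or longer chain than the one ending in a phenyl ring in compound 2, compound 3 and compound 4.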